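Swapping methoxy for fluoro on a potent antiproliferative scaffold

The compounds below may be only part of what the source reports. "The series", "measured", "known", "first", "only" and "open" are said of these compounds alone.

compound 1 `COc1ccc(C2C=C(c3cc(OC)c(OC)c(OC)c3)NC(=S)N2)cc1` gives 103 nM
compound 2 `COc1cccc(C2=CC(c3ccc(Cl)cc3)NC(=S)N2)c1` gives 150 nM
compound 3 `COc1cccc(C(=O)C(O)C(Nc2ccc(F)c(Cl)c2)c2ccc(Br)cc2)c1` gives 9.9 nM

In a functional assay on MCF7 cells (Homo sapiens) for antiproliferative activity, read by sulforhodamine B assay, with a stated time of 48 h (a lower number here means a stronger inhibitor, a higher number a weaker inhibitor), compound 1 gives 103 nM and so lies within the scatter of compound 2 at 150 nM while compound 3 at 9.9 nM shows a lower number, beyond the scatter.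

The next compound to be tested is compound 4 `COc1cc(C2=CC(c3ccc(F)cc3)NC(=S)N2)cc(OC)c1OC` which departs from compound 1 in one place. It carries fluoro in place of methoxy on an aromatic carbon, para to a large group, so that a 4-methoxyphenyl becomes a 4-fluorophenyl fluoro in place of methoxy on an aromatic carbon while the rest of the core of compound 1 stays the same.

Among the measured compounds shown here, no measured pair shows this change on its own, so any expectation rests on thin evidence. For the measured compounds named here, compound 2, which also carries a halogen on an aromatic ring, gives 150 nM and offers the only nearby guide. A small rise in the number, within the scatter, is therefore expected in this assay and the estimated step is a 1.5-fold higher number from compound 1 to compound 4 (0.16 log units; within the scatter) for this swap. Compound 4 is estimated at 150 nM (expected range 50 nM to 450 nM).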

Compound 4, half-maximal inhibitory concentration: 125 nM
Beside the measured number, compound 4's estimate is 1.2-fold (0.08 log units) above it; measured number inside the range.
By their numbers in this assay, from the lowest: compound 3; then compounds 1, 4 and 2 (each within the scatter of the next).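

In this assay the swap gives a 1.2-fold higher number from compound 1 to compound 4 (0.08 log units; within the scatter), so a 4-fluorophenyl in place of a 4-methoxyphenyl leaves the reading within the scatter. Among the compounds shown here, this is the first pair that differs in one place, and it shows that, on an aromatic carbon para to a large group, the methoxy and its hydrogen-bond acceptor can give way to a single fluoro with no change beyond the scatter on the core of compound 1. No supporting measurement bears on this result, so the pair records that the two groups read alike but offers no explanation for it.

From the compounds shown here alone, what stays open is how far this position accepts other groups, since one pair cannot show how a hydroxyl, an amine, a carboxylic acid or a longer chain such as ethoxy would read there. Nor can it show whether fluoro in place of methoxy would give a similar step on a different core or in a different cell line.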